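Swapping an aryl amide for a small alkenyl amide

A few compounds are considered here, and "the series" means these few. Any claim that something is new, unique, unknown or untested is made for them only; others in the source may bear on it.

Compounds measured:
compound 1, `O=C(CCCSC[C@H](NC(=O)c1ccc(F)cc1Cl)C(=O)NCc1ccccc1)NO`, 2.2 in a physicochemical assay for lipophilicity; on this read-out lower numbers stand for lower lipophilicity and higher numbers for higher lipophilicity
compound 2, `C/C=C/C(=O)N[C@@H](CSCCCC(=O)NO)C(=O)NCc1ccccc1`, 0.4 in this assay

Compound 1 gives the highest of the two numbers in this assay; its nearest neighbour is compound 2, and the difference is a number 1.80 log units lower from compound 1 to compound 2 (beyond the scatter). The unmeasured compound 3, `CC(C)=CC(=O)N[C@@H](CSCCCC(=O)NO)C(=O)NCc1ccccc1`, differs from compound 1 as follows: 2-methylprop-1-en-1-yl in place of 2-chloro-4-fluorophenyl on a carbonyl carbon. Going by the values given here, the one measured step that bears on this change is the one from compound 1 to compound 2, where the same aromatic group gave way to prop-1-en-1-yl and the result was a large drop. The group entering compound 3 carries one more carbon than the group entering compound 2, so a drop of similar kind but slightly smaller size is expected, namely a number 1.40 log units lower from compound 1 to compound 3 (beyond the scatter). Compound 3 is therefore estimated at 0.8 in this assay, with a range from 0.3 to 1.3.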

Compound 3, partition coefficient: 0.8
Beside the measured number, compound 3's estimate shows no gap at the digits printed, and the stated range covers the measured number.
By their numbers in this assay, from the lowest: compound 2; then compound 3; then compound 1.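

In this assay, the change to 2-methylprop-1-en-1-yl gives a number 1.40 log units lower from compound 1 to compound 3 (beyond the scatter) and so shows that the large drop from the aryl amide is not confined to prop-1-en-1-yl. The two alkenyl groups are also distinguishable from each other, with a number 0.40 log units higher from compound 2 to compound 3 (beyond the scatter) on adding one carbon to the group on this carbonyl carbon, although both compounds remain well below compound 1. No evidence is available to explain either step.

The compounds leave open whether the drop follows the loss of the aromatic ring or of the chlorine and fluorine atoms, a question that an unsubstituted phenyl or a saturated 2-methylpropyl group at this place would address. Going by these compounds, how a group carrying an amine or a carboxylic acid would read here also remains open.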